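Removing the aryl carboxylate from a sulfonamide series

A few compounds are considered here, and "the series" means these few. Any claim that something is new, unique, unknown or untested is made for them only; others in the source may bear on it.

Among the three measured compounds, compound 3 `O=C(O)CCC/C=C\C[C@H]1[C@@H]2CCC(C2)[C@@H]1NS(=O)(=O)c1ccc(C(=O)O)cc1` gives the highest number in a functional assay (plasma) for inhibition, with Oryctolagus cuniculus as the target (a higher number here means a weaker inhibitor, a lower number a stronger inhibitor), at 800000 nM. Compound 1 `O=C(O)CCC/C=C\C[C@H]1[C@@H]2CCC(C2)[C@@H]1NS(=O)(=O)c1ccc(F)cc1` gives 600 nM and compound 2 `COc1ccc(S(=O)(=O)N[C@H]2C3CC[C@H](C3)[C@@H]2C/C=C\CCCC(=O)O)cc1` gives 1700 nM in this assay, so compound 3 sits far above both, with steps of a 1300-fold higher number from compound 1 to compound 3 (3.12 log units; beyond the scatter) and a 470-fold higher number from compound 2 to compound 3 (2.67 log units; beyond the scatter). Compound 4 `CS(=O)(=O)N[C@H]1C2CC[C@H](C2)[C@@H]1C/C=C\CCCC(=O)O` differs from compound 3 as follows: methyl in place of 4-carboxyphenyl on a sulfonyl sulfur. Among the measured compounds shown here, both large steps onto compound 3 came with the carboxy entering the aromatic ring, and that carboxy is what leaves here, so a large fall in the number is expected, although a methyl has no precedent in this set, so the aryl-bearing values are not expected to be fully regained. Compound 4 is therefore estimated at 10000 nM in this assay, in the range 1500 nM to 80000 nM, an expected step of an 80-fold lower number from compound 3 to compound 4 (1.90 log units; beyond the scatter).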

Compound 4, half-maximal inhibitory concentration: 640000 nM
For compound 4 the middle estimate is 64-fold (1.81 log units) below the measured one, and the stated range ends below it.
By their numbers in this assay, from the lowest: compound 1; then compound 2; then compounds 4 and 3 (each within the scatter of the next).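

In this assay, methyl in place of 4-carboxyphenyl on the sulfonyl sulfur gives (a 1.3-fold lower number from compound 3 to compound 4 (0.10 log units; within the scatter)), so losing the carboxy together with the ring does not bring back the numbers of the other two aryl compounds. Methyl stands far from both of those (a 380-fold higher number from compound 2 to compound 4 (2.58 log units; beyond the scatter)) and (a 1100-fold higher number from compound 1 to compound 4 (3.03 log units; beyond the scatter)), so at this position 4-fluorophenyl and 4-methoxyphenyl give far lower numbers than methyl. The material shown offers no explanation for these differences. Still open, on these data alone, is how an unsubstituted phenyl or a longer chain such as butyl would compare with methyl.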